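The source may hold more compounds than are shown below. What is called first, only, known or untested is meant among the compounds shown, and "the series" means these compounds.

In a functional assay on HCT-15 cells (Homo sapiens) for inhibition (on this read-out lower numbers stand for stronger inhibition and higher numbers for weaker inhibition), compound 2, `Oc1cccc(-c2cc(-c3ccc(F)cc3)cc(-c3ccccc3O)n2)c1`, gives only a limit, > 50000 nM. Compound 1, `Oc1ccccc1-c1cc(-c2ccc(F)cc2)cc(-c2ccccc2O)n1`, likewise sits at a limit, with > 50000 nM. Among the measured compounds shown here, compound 3, `Oc1ccc(-c2cc(-c3ccc(F)cc3)cc(-c3cccc(O)c3)n2)cc1`, gives 5020 nM, so an at least 9.9-fold lower number from compound 2 to compound 3 (0.99 log units; beyond the scatter) is the one readable step, while a step that the two limits leave unreadable from compound 1 to compound 2 stays hidden behind (the limit of > 50000 nM in this assay, at which 2 of the 3 values shown sit). Compound 4, `Oc1cccc(-c2cc(-c3ccc(C(F)(F)F)cc3)cc(-c3ccccc3O)n2)c1`, differs from compound 2 by trifluoromethyl in place of fluoro on an aromatic carbon. For the measured compounds named here, both measured steps move the hydroxyphenyl on the shared core and leave the fluorophenyl untouched, so no measured step bears on this change. Since compound 2 stands at a limit, the expected step of a number no higher from compound 2 to compound 4 (the limit leaves the size open) has no firm footing. Compound 4 is therefore expected to remain near that limit, estimated at 50000 nM, within 15000 nM to 200000 nM.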

Compound 4, half-maximal inhibitory concentration: > 50000 nM
Compound 4: only a limit was reported; the forecaster's own chance of this, stated with the estimate: 70%; the middle value sits exactly at the limit.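

Among the compounds shown here, compound 2 and compound 4 both stand at a limit, so no step between them can be read: the limit of > 50000 nM in this assay, at which 3 of the 4 values shown sit. The compounds shown leave open how trifluoromethyl and fluoro compare where inhibition gives a readable number.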